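Chloro to methyl on the anilino group of compound 3

The compounds below may be only part of what the source reports. "The series", "measured", "known", "first", "only" and "open" are said of these compounds alone.

Compound 1 `CCCCCCCCNc1nc(SCc2ccc(C(F)(F)F)cc2)nc2ccccc12` carries an octyl chain on the ring nitrogen; in a functional assay on MCF7 cells (Homo sapiens) for cytotoxicity, read by MTT assay, with a stated time of 72 h (a higher number here means a weaker inhibitor, a lower number a stronger inhibitor), compound 1 gives 26100 nM. Compound 2 `FC(F)(F)c1ccc(CSc2nc(Nc3ccccc3C(F)(F)F)c3ccccc3n2)cc1` carries 2-(trifluoromethyl)phenyl in its place. In this assay compound 2 reaches only the limit of > 50000 nM. Compound 3 `FC(F)(F)c1ccc(CSc2nc(Nc3ccccc3Cl)c3ccccc3n2)cc1` carries 2-chlorophenyl instead. In this assay compound 3 likewise sits at the limit of > 50000 nM. Compound 3 therefore stands without a number of its own: there is an at least 1.9-fold higher number from compound 1 to compound 3 (0.28 log units; that floor lies within the scatter), matching an at least 1.9-fold higher number from compound 1 to compound 2 (0.28 log units; that floor lies within the scatter), while a step that the two limits leave unreadable from compound 2 to compound 3.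

Compound 4 `Cc1ccccc1Nc1nc(SCc2ccc(C(F)(F)F)cc2)nc2ccccc12` differs from compound 3 by methyl in place of chloro on an aromatic carbon. The step that bears on it most directly is the earlier swap of one small group on the same aromatic carbon, and that one is unreadable; the two steps from the octyl compound give only floors that lie within the scatter. No move beyond the scatter is expected in this assay. Compound 4 is estimated at 70000 nM, with a range of 25000 nM to 200000 nM. The step that the limit leaves unreadable from compound 3 to compound 4 is expected to be nothing readable, a further limit being the likelier outcome.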

Compound 4, half-maximal inhibitory concentration: 37500 nM
Estimate against measurement, compound 4: 1.9-fold (0.27 log units) above; the measured number falls inside the stated range.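

Among the aryl groups on this nitrogen, 2-methylphenyl is the first to give a number rather than a limit in this assay. Against the octyl chain there is a 1.4-fold higher number from compound 1 to compound 4 (0.16 log units; within the scatter), so the two groups are not told apart in this assay. Against the chloro and trifluoromethyl compounds there are an at least 1.3-fold lower number from compound 3 to compound 4 (0.12 log units; that floor lies within the scatter) and an at least 1.3-fold lower number from compound 2 to compound 4 (0.12 log units; that floor lies within the scatter), and these remain floors because compounds 2 and 3 are held at a limit of the assay: the limit of > 50000 nM in this assay, at which 2 of the 4 values shown sit.

As far as these compounds go, whether a methoxy group or an amine on the same aromatic carbon, or a shorter alkyl chain in place of octyl on the nitrogen, would move the number beyond the scatter stays open. Also open, from the compounds shown here alone, is how far the true values of compound 2 and compound 3 lie from that of compound 4.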